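The source may report more compounds than this note shows. Statements on the series, on what has been measured and on what is new or still open speak of the compounds shown alone.

Measured so far:
compound 1, `Oc1ccc(-c2cc(-c3cccs3)cc(-c3cccc(O)c3)n2)cc1`: 1890 nM
compound 2, `Oc1ccc(-c2cc(-c3cccs3)cc(-c3ccc(O)cc3)n2)cc1`: 2190 nM
compound 3, `Oc1cccc(-c2cc(-c3ccsc3)cc(-c3ccccc3O)n2)c1`: in this assay only a limit, > 50000 nM

In a functional assay on DU-145 cells (Homo sapiens) for cytotoxicity, read by CCK-8 assay (a lower number here means a stronger inhibitor, a higher number a weaker inhibitor), compound 2 gives the highest of the two numbers; nearest is compound 1, a difference a 1.2-fold higher number from compound 1 to compound 2 (0.06 log units; within the scatter) that stays within the scatter. Compound 4, `Oc1ccc(-c2cc(-c3ccsc3)cc(-c3ccc(O)cc3)n2)cc1`, is not yet measured. It differs from compound 2 by thiophen-3-yl in place of thiophen-2-yl on an aromatic carbon. Within the data shown here, no measured step changes the thiophene attachment alone; compound 3 carries thiophen-3-yl but differs from compound 2 in more than one place and gives only a limit. Among the measured compounds shown here, the single measured step, a 1.2-fold higher number from compound 1 to compound 2 (0.06 log units; within the scatter), concerns the hydroxyphenyl and is within the scatter. A step of a 1.6-fold higher number from compound 2 to compound 4 (0.20 log units; within the scatter) is therefore expected, possibly toward a weaker inhibitor, with wide uncertainty. Compound 4 is estimated at 3500 nM, between 1200 nM and 12000 nM.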

Compound 4, half-maximal inhibitory concentration: 2060 nM
Compound 4: the middle estimate sits 1.7-fold (0.23 log units) above what was measured; the range from low to high includes it.
By their numbers in this assay, from the lowest: compounds 1, 4 and 2 (each within the scatter of the next). At a limit, above all of these: compound 3.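

Compound 4 shows that at this position, opposite the ring nitrogen, thiophen-3-yl and thiophen-2-yl cannot be told apart in this assay: a 1.1-fold lower number from compound 2 to compound 4 (0.03 log units; within the scatter). Among these compounds, with the two 4-hydroxyphenyl groups the same in both compounds, this is the first readable change at this position, and it stays within the scatter. Nothing measured here accounts for this result.

Among the compounds shown here, compound 3 gives only a limit, > 50000 nM, and differs from compound 4 in more than one place; no step to it can be read. Going by these compounds, whether an amine or a carboxylic acid in place of the thiophene would give a similar number remains open.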